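The source may report more compounds than this note shows. Statements on the series, on what has been measured and on what is new or still open speak of the compounds shown alone.

In a functional assay on OVCAR-5 cells (Homo sapiens) for inhibition (a lower number here means a stronger inhibitor of growth, a higher number a weaker inhibitor of growth), compound 1 (`COc1cc(/C=C/C(=O)c2cccc(-n3cc(-c4ccc(Cl)cc4)[nH]c3=O)c2)cc(OC)c1OC`) gives 3110 nM. Two relatives offer a comparison: compound 2 (`O=C(/C=C/c1cccc(O)c1)c1cccc(-n2cc(-c3ccccc3)[nH]c2=O)c1`) gives 5440 nM and compound 3 (`O=C(/C=C/c1cccc(O)c1)c1cccc(-n2cc(-c3ccc(Cl)cc3)[nH]c2=O)c1`) gives 2190 nM. The value of compound 1 lies within the usual scatter of both, so it cannot be clearly separated from either, although compound 2 and compound 3 do differ beyond the scatter.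

Compound 4 (`COc1ccc(-c2cn(-c3cccc(C(=O)/C=C/c4cc(OC)c(OC)c(OC)c4)c3)c(=O)[nH]2)cc1`) keeps the core of compound 1 and changes one group: methoxy in place of chloro on an aromatic carbon. In words, this is methoxy in place of chloro on an aromatic carbon, para to a large group, turning 4-chlorophenyl into 4-methoxyphenyl.

Within the data shown here, no measured pair makes this exact swap. The nearest evidence is a change on the same phenyl group, chloro in place of hydrogen, which gave a 2.5-fold lower number from compound 2 to compound 3 (0.40 log units; beyond the scatter). That step is modest, and the pair also differs from compound 1 elsewhere in the structure. It shows that a single group here can shift the number somewhat, but it does not show which way methoxy would push it. No step beyond the scatter is therefore expected, and the estimated change is a 1.0-fold lower number from compound 1 to compound 4 (0.02 log units; within the scatter).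

For compound 4 the expected value is 3000 nM, with an estimated range from 1300 nM to 7000 nM.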

Compound 4, concentration for 50% growth inhibition: 2640 nM
For compound 4 the middle estimate is 1.1-fold (0.06 log units) above the measured one; the measured number falls inside the stated range.
By their numbers in this assay, from the lowest: compounds 3, 4, 1 and 2 (each within the scatter of the next, the first and the last beyond it).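

In this assay, methoxy in place of chloro gives a 1.2-fold lower number from compound 1 to compound 4 (0.07 log units; within the scatter), so at this position, para to a large group, turning 4-chlorophenyl into 4-methoxyphenyl leaves the number where it was within the usual scatter. Among these compounds, the only earlier step on this phenyl group, chloro in place of hydrogen, gave a 2.5-fold lower number from compound 2 to compound 3 (0.40 log units; beyond the scatter), which showed that a change here can move the number, though that pair differs from compound 1 elsewhere in the structure; the new step shows that not every change here does, even though methoxy brings two heavy atoms and a hydrogen-bond acceptor where chloro has one heavy atom and no acceptor. Nothing measured here explains why these two groups give such similar numbers.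

Going by these compounds, it remains open whether plain hydrogen at this position on the core of compound 1 would give a number clearly apart from those of compound 1 and compound 4. Also open, on these data alone, is whether a quite different group here, such as an amine, a carboxylic acid or a longer chain like butoxy, would keep the number in this range or shift it beyond the scatter.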